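The source may report more compounds than this note shows. Statements on the series, on what has been measured and on what is new or still open speak of the compounds shown alone.

Values so far in a functional assay on HepG2 cells (Homo sapiens) for cytotoxicity, read by MTT assay, with a stated time of 72 h; a higher number here means a weaker inhibitor, a lower number a stronger inhibitor:
- compound 1 `Cc1cc(C)cc(-n2c(Nc3ccccc3)nc3cnc(Nc4ccc(N5CCN(C)CC5)cc4)nc32)c1`: > 5000 nM (a limit)
- compound 2 `CC1CCN(c2ccc(Nc3ncc4nc(Nc5ccccc5)n(C5CCCC5)c4n3)cc2)CC1`: > 5000 nM (a limit)
- compound 3 `Cc1cccc(Nc2nc3cnc(Nc4ccc(N5CCN(C)CC5)cc4)nc3n2C2CCCC2)c1`: 4700 nM

Among the compounds with values here, compound 3 carries the only actual number in the set, 4700 nM. The readings for compound 1 and compound 2 are limits of the assay, not numbers. What the set mostly shows is therefore (the limit of > 5000 nM in this assay, at which 2 of the 3 values shown sit).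

The next compound to read is compound 4 `CN1CCN(c2ccc(Nc3ncc4nc(Nc5cc(Cl)ccc5Cl)n(C5CCCC5)c4n3)cc2)CC1`. It keeps the rest of compound 3 and carries 2,5-dichlorophenyl in place of 3-methylphenyl on a nitrogen on an aromatic ring. The counted difference is 2,5-dichlorophenyl in place of 3-methylphenyl on a nitrogen on an aromatic ring.

Within the data shown here, no pair of measured compounds differing in one place is available, so the series offers no measured step to scale this change against. Among the measured compounds shown here, the only anchor is compound 3 at 4700 nM. On that basis, no step beyond the usual scatter is expected in this assay, and no direction is favoured. A reading that returns only a limit is also a real possibility.

The expected change is a 1.2-fold lower number from compound 3 to compound 4 (0.07 log units; within the scatter), and this is an estimate only. For compound 4 the estimated value is 4000 nM, with an expected range of 1800 nM to 9000 nM.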

Compound 4, half-maximal inhibitory concentration: > 5000 nM
Compound 4: no number, only a limit (the forecaster's own chance of this, stated with the estimate: 45%); middle value at least 1.2-fold (0.09 log units) away from the limit.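

In this assay compound 4 gives > 5000 nM, which is a limit of the assay and not a number. Within the data shown here, at this position, on a nitrogen on an aromatic ring, 2,5-dichlorophenyl in place of 3-methylphenyl gives the first measured step, an at least 1.0-fold higher number from compound 3 to compound 4 (0.02 log units; that floor lies within the scatter); only a floor is printed, so the true size of the step stays unknown and the change cannot be told apart from no change. The reading adds one more compound to the set that returns no number, and compound 3 remains the only compound with an actual value: the limit of > 5000 nM in this assay, at which 3 of the 4 values shown sit.

Open, as far as these compounds go, is whether a single chlorine, as in 3-chlorophenyl or 2-chlorophenyl, would read any differently from 2,5-dichlorophenyl at this position. Also open, from the compounds shown here alone, is whether a quite different group on the same nitrogen, such as a phenyl ring carrying a carboxylic acid or an amine, or a plain alkyl chain in place of the ring, would return a number rather than a limit in this assay.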